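Chloro for fluoro on the distal aryl ring

A few compounds are considered here, and "the series" means these few. Any claim that something is new, unique, unknown or untested is made for them only; others in the source may bear on it.

Measured so far:
compound 1, `COc1ccccc1N1CCN(CCCCC(=O)NCc2ccccc2-c2cccc(F)c2)CC1`, 34.7 nM in an assay on CHO-K1 cells for displacement of a labelled ligand from 5-hydroxytryptamine receptor 7 (Homo sapiens), read by scintillation counting; on this read-out lower numbers stand for stronger inhibition and higher numbers for weaker inhibition
compound 2, `COc1ccccc1N1CCN(CCCC(=O)NCc2ccccc2-c2ccccc2)CC1`, 64.5 nM

Of the two numbers, compound 1 sits at the low end; its gap to compound 2 is within the scatter, so the two stand level. Compound 3 is `COc1ccccc1N1CCN(CCCCC(=O)NCc2ccccc2-c2cccc(Cl)c2)CC1` and differs from compound 1 by chloro in place of fluoro on an aromatic carbon. For the measured compounds named here, no step of this kind between measured compounds is available. Exchanging one halogen for another on that aromatic carbon is expected to move this assay little, probably not beyond the scatter. Compound 3 is therefore estimated at 30 nM, range 12 nM to 80 nM, with the expected step of a 1.2-fold lower number from compound 1 to compound 3 (0.06 log units; within the scatter) staying within the scatter.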

Compound 3, inhibition constant: 405 nM
The estimate for compound 3 lay 14-fold (1.13 log units) below the measured number; measured number above the stated range.
By their numbers in this assay, from the lowest: compounds 1 and 2 (each within the scatter of the next); then compound 3.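

The exchange of 3-fluorophenyl to 3-chlorophenyl is not a silent halogen swap: in this assay it gives a 12-fold higher number from compound 1 to compound 3 (1.07 log units; beyond the scatter). This aromatic carbon therefore discriminates sharply between two single halogens, although the count of hydrogen-bond donors, hydrogen-bond acceptors and net charge stays the same. No measurement shown here bears on what lies behind this step.

On these data alone, it remains open whether a bromo, methyl or methoxy group on this carbon tracks fluoro or chloro. Also open, as far as these compounds go, is whether the step persists with a shorter chain.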